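Shifting One Hydroxyl Group Against Colon Cancer Cells

The compounds below may be only part of what the source reports. "The series", "measured", "known", "first", "only" and "open" are said of these compounds alone.

Of the compounds shown here, three built on a shared core have been tested in a functional assay on HCT-15 cells (Homo sapiens) for cytotoxicity, read by CCK-8 assay, with a stated time of 4 days; a higher number here means a weaker inhibitor, a lower number a stronger inhibitor. Compound 1 `Oc1ccc(-c2cc(-c3cccc(O)c3)nc(-c3cccc(O)c3)c2)cc1` gives 3810 nM, compound 2 `Oc1ccccc1-c1cc(-c2ccccc2O)nc(-c2ccccc2O)c1` gives 2180 nM, and compound 3 `Oc1cccc(-c2cc(-c3ccccc3O)cc(-c3cccc(O)c3)n2)c1` gives 5150 nM. Compound 1 differs from compound 3 by 4-hydroxyphenyl in place of 2-hydroxyphenyl on an aromatic carbon, and that change gave a 1.4-fold lower number from compound 3 to compound 1 (0.13 log units; within the scatter). The difference between the cores of compound 2 and compound 3 is not broken down here. Compound 4 `Oc1ccc(-c2cc(-c3ccccc3O)cc(-c3ccccc3O)n2)cc1` has not been measured; it differs from compound 2 by 4-hydroxyphenyl in place of 2-hydroxyphenyl on an aromatic carbon. This is the same kind of change as that from compound 3 to compound 1, but the place differs: next to the ring nitrogen and meta to two 2-hydroxyphenyl groups, rather than meta to two 3-hydroxyphenyl groups and opposite the ring nitrogen. Compound 4 is expected to land near 1800 nM, between 900 nM and 3600 nM, because a 1.4-fold lower number from compound 3 to compound 1 (0.13 log units; within the scatter) was a small step. This amounts to an expected 1.2-fold lower number from compound 2 to compound 4 (0.08 log units; within the scatter).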

Compound 4, half-maximal inhibitory concentration: 8240 nM
Estimate against measurement, compound 4: 4.6-fold (0.66 log units) below, outside the stated range (above it).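

Exchanging 2-hydroxyphenyl for 4-hydroxyphenyl on the core of compound 2 gave a 3.8-fold higher number from compound 2 to compound 4 (0.58 log units; beyond the scatter) in this assay. Set beside the earlier case, the same exchange did not behave alike on the two cores: the same change on two cores in this assay, a 1.4-fold lower number (0.13 log units; within the scatter) from compound 3 to compound 1 and a 3.8-fold higher number (0.58 log units; beyond the scatter) from compound 2 to compound 4, 5.1-fold (0.71 log units) apart, beyond the scatter of two such steps

So the size of this step, and even its direction, cannot simply be carried from one core to the other in this series, although two cases do not show why they part or what a further core would do.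

The compounds shown carry only hydroxyphenyl groups on the shared core. As far as these compounds go, what a methoxy group or an amine would do in place of the hydroxyl on compound 4 therefore stays open.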